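The source may report more compounds than this note shows. Statements on the series, on what has been measured and on what is new or still open speak of the compounds shown alone.

In an ADME assay on HUVEC cells (Homo sapiens) for cytotoxicity, read by MTT assay, with a stated time of 24 h (a higher number here means that more compound is tolerated, a lower number that less compound is tolerated), three compounds that share one core have been measured. Compound 1 `Cc1ccc(/C=C/c2nnc(-c3ccc4c(c3)OCCO4)o2)cc1` gives 265000 nM, compound 2 `Fc1ccc(/C=C/c2nnc(-c3ccc4c(c3)OCCO4)o2)cc1` gives 325000 nM, and compound 3 `Clc1ccccc1/C=C/c1nnc(-c2ccc3c(c2)OCCO3)o1` gives 368000 nM. Compound 3 therefore stands level with the other two, as its gaps to both lie within the usual scatter of repeated measurements.

The next structure, compound 4 `Cc1ccccc1/C=C/c1nnc(-c2ccc3c(c2)OCCO3)o1`, differs from compound 3 in a single group: methyl in place of chloro on an aromatic carbon. In words, this places methyl in place of chloro on an aromatic carbon. Among the compounds with values here, no measured pair makes exactly this change, so the evidence is indirect. Within the data shown here, three measured steps bear on it. Fluoro in place of methyl gave a 1.2-fold higher number from compound 1 to compound 2 (0.09 log units; within the scatter). 2-chlorophenyl in place of 4-methylphenyl gave a 1.4-fold higher number from compound 1 to compound 3 (0.14 log units; within the scatter), and 2-chlorophenyl in place of 4-fluorophenyl gave a 1.1-fold higher number from compound 2 to compound 3 (0.05 log units; within the scatter). All three stay within the scatter, so no change beyond the scatter is expected in this assay, and the data fix no firm direction. The estimated step is a 1.2-fold lower number from compound 3 to compound 4 (0.07 log units; within the scatter), which is expected to remain within the scatter. For compound 4, the estimated value is 310000 nM, with an expected range from 190000 nM to 500000 nM.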

Compound 4, half-maximal cytotoxic concentration: 356000 nM
The estimate for compound 4 lay 1.1-fold (0.06 log units) below the measured number, and the stated range covers the measured number.
By their numbers in this assay, from the lowest: compounds 1, 2, 4 and 3 (each within the scatter of the next).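

In this assay, within the data shown here, methyl in place of chloro on an aromatic carbon ortho to a large group gives a 1.0-fold lower number from compound 3 to compound 4 (0.01 log units; within the scatter), which is the first direct reading of this swap: at this position, the two groups cannot be told apart. The comparisons with the other phenyl groups fit the same picture, with 2-methylphenyl in place of 4-fluorophenyl giving a 1.1-fold higher number from compound 2 to compound 4 (0.04 log units; within the scatter) and 2-methylphenyl in place of 4-methylphenyl giving a 1.3-fold higher number from compound 1 to compound 4 (0.13 log units; within the scatter), so the methyl group placed at either of these two named ring positions also produces no difference beyond the scatter. Nothing available here accounts for how closely these compounds match.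

What an amine, a carboxylic acid or a longer chain would do on this aromatic carbon stays open, since the only groups shown on the phenyl ring are methyl, fluoro and chloro. Also open, on these data alone, is whether this level picture would hold if the shared core itself changed, as all four compounds carry it unaltered.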